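Chloro for methoxy on the aryl group of compound 1

This account rests on a few compounds, and the source may have more. Where it says the series, first, only, none or still open, it means among the compounds named here.

Of the compounds shown here, two have been measured so far in an assay on CHO cells for displacement of a labelled ligand from adenosine receptor A3 (Homo sapiens), read by scintillation counting, with a stated time of 3 h; on this read-out lower numbers stand for stronger inhibition and higher numbers for weaker inhibition. Compound 1 `COc1ccc(-c2nc3c(NC4CCCC4)ncnc3n2C)cc1` gives 1850 nM in this assay. Compound 2 `CCCn1c(-c2ccccc2)nc2c(NC3CCCCC3)ncnc21` differs from compound 1 in several places at once, and in this assay compound 2 gives 2360 nM. The two values lie within the scatter of each other, so neither compound stands apart from the other on the numbers known.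

Compound 3 `Cn1c(-c2ccc(Cl)cc2)nc2c(NC3CCCC3)ncnc21` is not yet measured. It differs from compound 1 in one place: chloro in place of methoxy on an aromatic carbon. Within the data shown here, no measured pair isolates a change of this kind, so no step in this assay is at hand to lean on. The expected step of a 1.5-fold lower number from compound 1 to compound 3 (0.19 log units; within the scatter) is small, if anything toward a lower number, and not beyond the scatter. The estimate for compound 3 in this assay is 1200 nM, with a range from 400 nM to 3600 nM.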

Compound 3, inhibition constant: 1210 nM
Compound 3: the middle estimate sits 1.0-fold (0.00 log units) below what was measured; low and high end bracket the measured number.
By their numbers in this assay, from the lowest: compounds 3, 1 and 2 (each within the scatter of the next).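

In this assay, among these compounds, the one pair that differs in a single place reads a 1.5-fold lower number from compound 1 to compound 3 (0.18 log units; within the scatter), so 4-methoxyphenyl and 4-chlorophenyl are not told apart at this position. Methoxy carries a hydrogen-bond acceptor and chloro carries none, yet on the aromatic carbon para to a large group this exchange gives no step beyond the scatter. No separate measurement bears on why the two groups read alike.

On these data alone, whether a group of another kind at this place, such as an amine, a carboxylic acid or a longer alkoxy chain, would give a step beyond the scatter remains open. Compound 2 differs from compound 1 in several places at once, so the contribution of each other part of the structure also remains unresolved.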